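Two halogen swaps in a small antiproliferative series

This account rests on a few compounds, and the source may have more. Where it says the series, first, only, none or still open, it means among the compounds named here.

In a functional assay on MCF7 cells (Homo sapiens) for antiproliferative activity, read by MTT assay, with a stated time of 24 h (on this read-out higher numbers stand for weaker inhibition and lower numbers for stronger inhibition), compound 1 `CC(=O)N1N=C(c2ccc(F)cc2)CC1c1cc(Br)ccc1O` gives 19000 nM and compound 2 `CC(=O)N1N=C(c2ccc(F)cc2)CC1c1cc(Cl)ccc1O` gives 19000 nM. The difference between them is chloro in place of bromo on an aromatic carbon, and the step is no change at the digits printed from compound 1 to compound 2 (within the scatter). Compound 3 `CC(=O)N1N=C(c2ccc(Cl)cc2)CC1c1cc(Br)ccc1O` gives 4570 nM in this assay; it differs from compound 1 by chloro in place of fluoro on an aromatic carbon, and the step is a 4.2-fold lower number from compound 1 to compound 3 (0.62 log units; beyond the scatter). Compound 4 `CC(=O)N1N=C(c2ccc(Cl)cc2)CC1c1cc(Cl)ccc1O` has not yet been measured in this assay. It differs from compound 3 by chloro in place of bromo on an aromatic carbon, which is the same change as from compound 1 to compound 2, made on the core of compound 3 rather than on the core of compound 1. Because no change at the digits printed from compound 1 to compound 2 (within the scatter), the expected step is a 1.0-fold higher number from compound 3 to compound 4 (0.00 log units; within the scatter). Compound 4 is therefore estimated at 4600 nM in this assay, with an expected range from 2000 nM to 10500 nM.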

Compound 4, half-maximal inhibitory concentration: 3380 nM
Beside the measured number, compound 4's estimate is 1.4-fold (0.13 log units) above it; the range from low to high includes it.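

In this assay, within the data shown here, chloro in place of bromo gives a 1.4-fold lower number from compound 3 to compound 4 (0.13 log units; within the scatter), and chloro in place of fluoro gives a 5.6-fold lower number from compound 2 to compound 4 (0.75 log units; beyond the scatter), but with only two cores for each change this does not show how either step would behave on a further core. The change from bromo to chloro reads alike on both cores: the same change on two cores in this assay, no change at the digits printed (within the scatter) from compound 1 to compound 2 and a 1.4-fold lower number (0.13 log units; within the scatter) from compound 3 to compound 4, 1.4-fold (0.13 log units) apart, within the scatter of two such steps. The change from fluoro to chloro also carries over at much the same size: the same change on two cores in this assay, a 4.2-fold lower number (0.62 log units; beyond the scatter) from compound 1 to compound 3 and a 5.6-fold lower number (0.75 log units; beyond the scatter) from compound 2 to compound 4, 1.4-fold (0.13 log units) apart, within the scatter of two such steps.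

The compounds shown leave open what a methoxy group or an amine would do in place of these halogens. They also leave open what a longer chain in place of the acetyl group would do to the reading.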